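The compounds below may be only part of what the source reports. "The series", "measured", "known", "first", "only" and "open" are said of these compounds alone.

The three measured compounds share one core, seen in compound 1 `O=C(Nc1cccc([N+](=O)[O-])c1)N1CCN(S(=O)(=O)c2sccc2-c2ccccc2Oc2ccc(O)c(O)c2)CC1`, compound 2 `COc1ccc(Oc2ccc(C(C)C)cc2-c2ccsc2S(=O)(=O)NCCNC(=O)Nc2cc(Cl)cc(Cl)c2)cc1OC` and compound 3 `Cc1ccc(-c2ccsc2S(=O)(=O)NCCNC(=S)Nc2ccc([N+](=O)[O-])cc2)c(Oc2ccc(O)c(O)c2)c1`. In a functional assay on RS4-11 cells (Homo sapiens) for inhibition, read by CCK-8 assay, with a stated time of 48 h (on this read-out lower numbers stand for stronger inhibition and higher numbers for weaker inhibition), compound 1 gives 9800 nM. In this assay compound 2 gives 9000 nM, and in the same this assay compound 3 gives 5100 nM. Among these three numbers compound 1 holds the highest, yet its gap to compound 2 and its gap to compound 3 both lie within the usual scatter of repeated measurements, so nothing here separates the three in strength of inhibition.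

Compound 4 `O=C(Nc1ccc(F)cc1)N1CCN(S(=O)(=O)c2sccc2-c2ccccc2Oc2ccc(O)c(O)c2)CC1` has not yet been measured. It differs from compound 1 in a single place: 4-fluorophenyl in place of 3-nitrophenyl on an amide-type nitrogen. Among the compounds with values here, no measured pair in this set carries that exchange, so the data give no reading of how it moves the result. The account therefore expects in this assay a step of a 1.0-fold lower number from compound 1 to compound 4 (0.01 log units; within the scatter), which is meant as no more than the scatter and with no direction favoured. On that basis the estimate for compound 4 in this assay is 9500 nM, with an expected range from 3000 nM to 30000 nM, pending the measurement.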

Compound 4, half-maximal inhibitory concentration: 6800 nM
For compound 4 the middle estimate is 1.4-fold (0.15 log units) above the measured one; low and high end bracket the measured number.
By their numbers in this assay, from the lowest: compounds 3, 4, 2 and 1 (each within the scatter of the next).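

Within the data shown here, the exchange gives the first reading at this position: in this assay, putting 4-fluorophenyl in place of 3-nitrophenyl on the amide-type nitrogen gives a 1.4-fold lower number from compound 1 to compound 4 (0.16 log units; within the scatter). The hydrogen-bond acceptors counted on 3-nitrophenyl leave and none enter with 4-fluorophenyl, and the ring also changes its substituent and where that substituent sits, yet the read-out does not separate the two compounds. This one exchange therefore shows no sign that the choice between these two substituted phenyl groups matters for inhibition here, and nothing in the shown data explains that outcome.

Going by these compounds, compound 2 and compound 3 differ from compound 1 and compound 4 in more than one place, so they give no second reading of this position, and whether the position can respond at all remains open. A carbon-only phenyl without a substituent, a benzyl group, a cyclohexyl group, or a phenyl ring carrying a carboxylic acid or a dimethylamino group on the same nitrogen could each test whether any replacement moves the number beyond the scatter.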